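Methoxy added to the fused ring of compound 2

A few compounds are considered here, and "the series" means these few. Any claim that something is new, unique, unknown or untested is made for them only; others in the source may bear on it.

Compound 2 `CCCCC1(CCCC)CS(=O)(=O)c2ccc(N(C)C)cc2[C@@H](c2ccc(OC)cc2)[C@H]1O` gives 7 nM in an assay on cells for inhibition of ileal sodium/bile acid cotransporter (Homo sapiens) (a lower number here means a stronger inhibitor, a higher number a weaker inhibitor), and carries the lowest of the three measured numbers, with compound 3 `CCCCC1(CCCC)CS(=O)(=O)c2ccc(N(C)C)cc2[C@@H](c2ccc(F)cc2)[C@H]1O` at 10 nM within the scatter of it: the step of a 1.4-fold higher number from compound 2 to compound 3 (0.15 log units; within the scatter). Compound 1 `CCCC[C@]1(CC)CS(=O)(=O)c2ccc(OC)cc2[C@@H](c2ccccc2)[C@H]1O` gives 55 nM, beyond the scatter from compound 2, but compound 1 differs from compound 2 in several places at once. Compound 4 `CCCCC1(CCCC)CS(=O)(=O)c2c(OC)cc(N(C)C)cc2[C@@H](c2ccc(OC)cc2)[C@H]1O` carries the change (methoxy in place of hydrogen on an aromatic carbon). For the measured compounds named here, no measured step touches this position of the shared core; the only single-point step, from compound 2 to compound 3, concerns a different aromatic carbon and stayed within the scatter. The step of a 1.1-fold higher number from compound 2 to compound 4 (0.06 log units; within the scatter) is therefore expected to stay within the scatter. Compound 4 is estimated at 8 nM, between 3 nM and 25 nM.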

Compound 4, half-maximal inhibitory concentration: 2 nM
Estimate against measurement, compound 4: 4.0-fold (0.60 log units) above; measured number outside the range, below it.
By their numbers in this assay, from the lowest: compound 4; then compounds 2 and 3 (each within the scatter of the next); then compound 1.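

Methoxy in place of hydrogen, ortho to a fused ring and meta to a dimethylamino group, gives in this assay a 3.5-fold lower number from compound 2 to compound 4 (0.54 log units; beyond the scatter) and so shows that this aromatic carbon of the shared core can move the number beyond the scatter. For the compounds shown here, the only earlier single-place step, a 1.4-fold higher number from compound 2 to compound 3 (0.15 log units; within the scatter) at a different aromatic carbon, showed no such shift. Nothing measured here bears on the reason for this step. As far as these compounds go, whether a hydroxy group, an amine or a longer chain such as ethoxy at this carbon would give a similar step stays open, as does whether methoxy here gives the same step on compound 3.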